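Swapping Isobutyl for Phenyl on a Shared Core

This account rests on a few compounds, and the source may have more. Where it says the series, first, only, none or still open, it means among the compounds named here.

Of the compounds shown here, three that share one core have been measured in a physicochemical assay for acid dissociation. Compound 1 `COc1cccc(CNCCCNc2ccnc3cc(C4CCCCC4)ccc23)c1O` gives 9.47. Compound 2 `c1ccc(-c2ccc3c(NCCCNCc4ccco4)ccnc3c2)cc1` gives 9.47. Compound 3 `COc1cccc(CNCCCNc2ccnc3cc(CC(C)C)ccc23)c1O` gives 9.47, so compound 3 stands level with compounds 1 and 2 at the digits shown, with compound 1 the nearest and compound 2 the furthest, both within the scatter. Within the data shown here, the only step between two compounds that differ in one place is no change at the digits printed from compound 1 to compound 3 (within the scatter), an isobutyl in place of a cyclohexyl on an aromatic carbon, and it left the read-out unchanged.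

Compound 4 `COc1cccc(CNCCCNc2ccnc3cc(-c4ccccc4)ccc23)c1O` has not yet been measured in this assay. It differs from compound 3 by phenyl in place of isobutyl on an aromatic carbon. The step that bears on this place is the one already described, no change at the digits printed from compound 1 to compound 3 (within the scatter), where a different group on the same aromatic carbon made no difference beyond the scatter. Compound 2, which also carries a phenyl on an aromatic carbon of its core, gives 9.47, the same value again. No change beyond the scatter is therefore expected in this assay. Compound 4 is expected to give 9.47, between 9.2 and 9.75. The implied step, no change at the digits printed from compound 3 to compound 4 (within the scatter), is expected to stay within the scatter.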

Compound 4, acid dissociation constant: 9.47
Compound 4: the middle estimate sits on the measured number at the digits printed; the range from low to high includes it.
By their numbers in this assay, from the lowest: compounds 1, 2, 3 and 4 (each within the scatter of the next).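

In this assay, among these compounds, the result for the phenyl is no change at the digits printed from compound 3 to compound 4 (within the scatter) and the result for the direct swap of the saturated ring for the aromatic one is no change at the digits printed from compound 1 to compound 4 (within the scatter) on the same aromatic carbon, which had so far been tested only with cyclohexyl and isobutyl. This position now reads level with a branched chain, a saturated ring and an aromatic ring of carbon only, and none of the compounds shown goes against that. Among the compounds shown here, compound 4 also gives the first step at a second place in the molecule, on a saturated chain carbon bound to an amine nitrogen, where 2-hydroxy-3-methoxyphenyl stands in place of furan-2-yl and the reading is no change at the digits printed from compound 2 to compound 4 (within the scatter) for that swap.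

Nothing available here accounts for why these numbers stay level. On these data alone, all the groups on this aromatic carbon so far are built of carbon alone, so it remains open whether an amine or a carboxylic acid there would read the same, and whether a longer chain carrying the amine nitrogen would do so either.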